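A few compounds are considered here, and "the series" means these few. Any claim that something is new, unique, unknown or untested is made for them only; others in the source may bear on it.

Of the compounds shown here, two sharing one core have been measured in a functional assay on SK-MEL-2 cells (Homo sapiens) for antiproliferative activity, read by sulforhodamine B assay, with a stated time of 48 h; a lower number here means a stronger inhibitor, a higher number a weaker inhibitor. Compound 1 `Nc1cccc2c(-c3cccc(NC(=O)c4ccc(Cl)c(C(F)(F)F)c4)c3)ccnc12` gives 3500 nM. Compound 2 `Nc1cccc2c(-c3cccc(NC(=O)c4ccc5c(c4)OCCO5)c3)ccnc12` reaches only the limit of this assay, > 20000 nM, and so stands at the limit of > 20000 nM in this assay, at which 1 of the 2 values shown sits. Compound 3 `Nc1cccc2c(-c3cccc(NC(=O)c4nccs4)c3)ccnc12` has not yet been measured. The change from compound 2 to compound 3 is 1,3-thiazol-2-yl in place of 2,3-dihydro-1,4-benzodioxin-6-yl on a carbonyl carbon. Going by the values given here, no measured pair shows this step, so its size is unknown from the data. A modest gain in this assay is expected, an at least 1.3-fold lower number from compound 2 to compound 3 (0.12 log units; that floor lies within the scatter). Compound 3 is expected to give 15000 nM, between 4000 nM and 60000 nM.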

Compound 3, half-maximal inhibitory concentration: 11300 nM
Beside the measured number, compound 3's estimate is 1.3-fold (0.12 log units) above it, and the stated range covers the measured number.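

In this assay, the 1,3-thiazol-2-yl group on the carbonyl carbon gives compound 3 a measured number, whereas the 2,3-dihydro-1,4-benzodioxin-6-yl group leaves compound 2 at a limit. This change gives an at least 1.7-fold lower number from compound 2 to compound 3 (0.24 log units; that floor lies within the scatter). From the compounds shown here alone, the true size of the step remains unknown, and only its floor can be read: the limit of > 20000 nM in this assay, at which 1 of the 3 values shown sits.

Going by these compounds, how far compound 3 truly lies from compound 2 remains open. Also open, on these data alone, is whether a simple amine or a carboxylic acid on this carbonyl carbon would move the number in either direction.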